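The compounds below may be only part of what the source reports. "The series", "measured", "known", "first", "only" and "open" are said of these compounds alone.

Measured so far in a functional assay on CHO-K1 cells for antagonist activity at C-X-C chemokine receptor type 3 (Homo sapiens), read by FLIPR, with a stated time of 10 min, in the presence of a further agent that is not named here; on this read-out lower numbers stand for stronger inhibition and higher numbers for weaker inhibition:
compound 1, `Cc1nc(C)n(CC(=O)N2CCN(c3sc(C(F)(F)F)nc3-c3nc4ccc(OC5CNC5)cc4[nH]3)C[C@H]2C)n1`, gives 3.8 nM
compound 2, `Cc1nc(C)n(CC(=O)N2CCN(c3sc(C(F)(F)F)nc3-c3nc4cccc(C)c4[nH]3)C[C@H]2C)n1`, gives 3.1 nM
compound 3, `Cc1nn(CC(=O)N2CCN(c3sc(C(F)(F)F)nc3-c3nc4ccccc4[nH]3)C[C@H]2C)cc1CN(C)C`, gives 2.7 nM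

The three numbers sit close together. Compound 2 holds the second highest of the three; its nearest neighbour is compound 3 and its furthest is compound 1, and both gaps lie within the usual scatter, so no order among the three can be read from them. Going by the values given here, no pair of measured compounds differs in a single place, so no step size is on hand to calibrate a change of this kind.

Compound 4, `Cc1nc(C)n(CC(=O)N2CCN(c3sc(C(F)(F)F)nc3-c3nc4c(F)cccc4[nH]3)C[C@H]2C)n1`, is to be measured in this assay. It differs from compound 2 as follows: 4-fluoro-1H-benzimidazol-2-yl in place of 7-methyl-1H-benzimidazol-2-yl on an aromatic carbon. The group that leaves and the group that enters have the same count of heavy atoms, donors and acceptors; a single carbon gives way to a single fluorine on the six-membered aromatic ring of carbon only.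

Among the compounds with values here, with no calibrating step available and three closely grouped values, the step from compound 2 to compound 4 in this assay is expected to be small, a 1.3-fold higher number from compound 2 to compound 4 (0.11 log units; within the scatter), and not beyond the scatter in either direction. Compound 4 is therefore estimated at 4 nM, within a range of 1.5 nM to 12 nM.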

Compound 4, half-maximal inhibitory concentration: 3.1 nM
Compound 4: middle estimate off by 1.3-fold (0.11 log units), on the high side; the range from low to high includes it.
By their numbers in this assay, from the lowest: compounds 3, 2, 4 and 1 (each within the scatter of the next).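

In this assay, going by these compounds alone, 4-fluoro-1H-benzimidazol-2-yl in place of 7-methyl-1H-benzimidazol-2-yl gives no change at the digits printed from compound 2 to compound 4 (within the scatter), the first step that changes one place only. At this position, on an aromatic carbon of the five-membered aromatic ring with nitrogen and sulfur, the two groups cannot be told apart in this read-out, so a fluorine on the six-membered ring serves as well as a methyl group does. No measurement at hand speaks to why the number holds.

Still open, going by these compounds, is whether the plain 1H-benzimidazol-2-yl group, with neither fluorine nor methyl, would read the same with the rest of compound 2 unchanged. Also open, on these data alone, is whether a carboxylic acid, a primary amine or a longer alkyl chain on the six-membered ring would keep the number in this range.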